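Enantiomer of compound 3: expected effect on nitrite inhibition

This account rests on a few compounds, and the source may have more. Where it says the series, first, only, none or still open, it means among the compounds named here.

In a functional assay on RAW264.7 cells (Rattus norvegicus) for inhibition, with RAW264.7 (Mus musculus) as the target, read by Griess assay, with stated times of 2 h and 16 h (a lower number here means a stronger inhibitor, a higher number a weaker inhibitor), compound 1 `O=C1c2ccccc2O[C@H](c2cccc(O)c2O)[C@H]1O` gives only a limit, > 100000 nM. Compound 2 `O=C1c2ccc(O)cc2O[C@H](c2cccc(O)c2O)[C@H]1O` gives 70700 nM, and the step of an at least 1.4-fold lower number from compound 1 to compound 2 (0.15 log units; that floor lies within the scatter) is capped by the limit (the limit of > 100000 nM in this assay, at which 1 of the 3 values shown sits). Compound 3 `COc1ccc2c(c1)O[C@@H](c1cccc(O)c1O)[C@H](O)C2=O` gives 30300 nM and stands lowest of the two numbers in hand, with compound 2 as its nearest neighbour at a gap beyond the scatter.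

Compound 4 `COc1ccc2c(c1)O[C@H](c1cccc(O)c1O)[C@@H](O)C2=O` differs from compound 3 as follows: the two compounds have the same atoms and bonds and differ only in configuration as drawn: 2 of 2 stereo elements differ (all stereocentres are inverted: mirror images); a stereocentre at a saturated ring carbon is drawn S in compound 3 and R in compound 4; a stereocentre at a saturated ring carbon is drawn S in compound 3 and R in compound 4. For the measured compounds named here, no measured step concerns an inversion of configuration, so none bears on this change, and the expectation rests on compound 3 alone. The step of a 1.0-fold lower number from compound 3 to compound 4 (0.00 log units; within the scatter) is therefore estimated as none beyond the scatter in either direction, with wide uncertainty. Compound 4 is expected to give about 30000 nM, between 8000 nM and 120000 nM, in this assay.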

Compound 4, half-maximal inhibitory concentration: 24600 nM
Beside the measured number, compound 4's estimate is 1.2-fold (0.09 log units) above it; the range from low to high includes it.
By their numbers in this assay, from the lowest: compounds 4 and 3 (each within the scatter of the next); then compound 2. At a limit, above all of these: compound 1.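

In this assay, for the compounds shown here, the mirror-image pair shows no separation, with a 1.2-fold lower number from compound 3 to compound 4 (0.09 log units; within the scatter), so inverting both stereocentres is the first change that leaves the two numbers within the scatter. Methylating the aromatic hydroxy oxygen now gives a step beyond the scatter in this configuration, with a 2.9-fold lower number from compound 2 to compound 4 (0.46 log units; beyond the scatter). Methoxy in place of hydrogen gives an at least 4.0-fold lower number from compound 1 to compound 4 (0.60 log units; beyond the scatter), a floor only, as the value of compound 1 is a limit: the limit of > 100000 nM in this assay, at which 1 of the 4 values shown sits.

Open, on these data alone, is whether an ethoxy group or an amine in place of the methoxy would move the number further. Also open, as far as these compounds go, is whether inverting only one stereocentre would separate from compounds 3 and 4.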